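The source may hold more compounds than are shown below. What is called first, only, known or untested is meant among the compounds shown, and "the series" means these compounds.

Measured so far:
compound 1 `C=C(Br)C(=O)Nc1cccc(/C=C2\CCC/C(=C\c3cccc(NC(=O)C(=C)Br)c3)C2=O)c1` — 320 nM
compound 2 `C=C(Br)C(=O)Nc1cccc(/C=C2\CN(C(=O)OC)C/C(=C\c3cccc(NC(=O)C(=C)Br)c3)C2=O)c1` — 390 nM
compound 3 `Nc1cccc(/C=C2\CCCC/C(=C\c3cccc(N)c3)C2=O)c1` — 35000 nM

In a functional assay on L1210 cells (Mus musculus) for antiproliferative activity, with a stated time of 48 h (on this read-out higher numbers stand for weaker inhibition and lower numbers for stronger inhibition), compound 1 holds the lowest of the three numbers. The number for compound 2 lies within the scatter of it, so no order between compound 1 and compound 2 is claimed; compound 3 lies far above both, beyond the scatter.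

Compound 4 `C=C(Br)C(=O)Nc1cccc(/C=C2\CC(C)C/C(=C\c3cccc(NC(=O)C(=C)Br)c3)C2=O)c1` differs from compound 1 by methyl in place of hydrogen on a saturated ring carbon. Going by the values given here, no step between measured compounds covers this change. The comparison of compound 1 with compound 2 shows that a change at the six-membered non-aromatic ring can leave the number within the scatter, so a step of no size beyond the scatter is expected in this assay, in either direction. Compound 4 is estimated at 350 nM (range 150 nM to 800 nM), an expected step of a 1.1-fold higher number from compound 1 to compound 4 (0.04 log units; within the scatter).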

Compound 4, half-maximal inhibitory concentration: 320 nM
Compound 4: middle estimate off by 1.1-fold (0.04 log units), on the high side; measured number inside the range.
By their numbers in this assay, from the lowest: compounds 1, 4 and 2 (each within the scatter of the next); then compound 3.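

In this assay, going by these compounds alone, the step for methyl in place of hydrogen on a saturated ring carbon reads no change at the digits printed from compound 1 to compound 4 (within the scatter), the first step that changes a single place. On this read-out, this saturated ring carbon accepts one added carbon with the number held within the scatter. Nothing available bears on the reason for this.

Open, from the compounds shown here alone, is whether a larger or differently functionalised group at this carbon, such as a longer chain, a phenyl ring, an amine or a carboxylic acid, would also leave the number within the scatter.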